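This account rests on a few compounds, and the source may have more. Where it says the series, first, only, none or still open, it means among the compounds named here.

Measured compounds:
Compound 1, `COc1ccc(OC)c(-c2cc(-c3ccc(Cl)cc3)nn2-c2ccc(S(=O)(=O)NC(C)=O)cc2)c1`, in a functional assay on cells (Cancer cell lines, Homo sapiens) for cytotoxicity, read by sulforhodamine B assay, with a stated time of 48 h (a lower number here means a stronger inhibitor of growth, a higher number a weaker inhibitor of growth), compound 1 gives 50000 nM.
Compound 2, `Oc1ccc(O)c(-c2cc(-c3ccc(Cl)cc3)nn2-c2ccccc2)c1`, in this assay compound 2 gives 34600 nM.
Compound 3, `CC(=O)NS(=O)(=O)c1ccc(-n2nc(-c3ccccc3)cc2-c2cc(O)ccc2O)cc1`, in this assay compound 3 gives 100000 nM.

Among these three numbers compound 3 stands highest, meaning it is the weakest inhibitor of growth of the set. Its nearest neighbour is compound 1, whose number is lower but within the usual scatter of this kind of measurement, so no real order between compound 3 and compound 1 can be read from the data. Compound 2 lies further away, its number being lower by more than the scatter, so compound 2 is a stronger inhibitor of growth than compound 3.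

Compound 4, `CC(=O)NS(=O)(=O)c1ccc(-n2nc(-c3ccc(Cl)cc3)cc2-c2cc(O)ccc2O)cc1`, has not yet been measured. It differs from compound 3 in one place: chloro in place of hydrogen on an aromatic carbon. Within the data shown here, both compound 1 and compound 2 already carry this 4-chlorophenyl group, and both give lower numbers than compound 3, but neither differs from compound 3 in this place alone, so no direct step is available to size the change.

The expected step of a 1.8-fold lower number from compound 3 to compound 4 (0.26 log units; within the scatter) is therefore a modest move toward a lower number, of a size that may not exceed the scatter. For compound 4 the estimated value in this assay is 55000 nM, with a range from 20000 nM to 120000 nM.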

Compound 4, concentration for total growth inhibition: 93900 nM
Estimate against measurement, compound 4: 1.7-fold (0.23 log units) below, and the stated range covers the measured number.
By their numbers in this assay, from the lowest: compounds 2, 1, 4 and 3 (each within the scatter of the next, the first and the last beyond it).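

In this assay, chloro in place of hydrogen, which turns phenyl into 4-chlorophenyl, gives a 1.1-fold lower number from compound 3 to compound 4 (0.03 log units; within the scatter) and so leaves no readable mark at this position, at least in a compound that carries the acetylsulfamoyl and 2,5-dihydroxyphenyl groups. Among these compounds, compound 4 also opens two further comparisons: adding the acetylsulfamoyl group gives a 2.7-fold higher number from compound 2 to compound 4 (0.43 log units; beyond the scatter) and is the only one of the three steps beyond the scatter, making compound 4 the weaker inhibitor of growth of that pair. By contrast, 2,5-dihydroxyphenyl in place of 2,5-dimethoxyphenyl gives a 1.9-fold higher number from compound 1 to compound 4 (0.27 log units; within the scatter) and shows no real difference between these two groups.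

Nothing measured here explains any of these steps. Going by these compounds, whether this position stays as unresponsive with a different group, such as fluoro, methoxy or an amine, remains open, as does whether a carboxylic acid or a plain sulfonamide in place of acetylsulfamoyl would give a number closer to that of compound 2.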